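Ether side group change: compound 2 to compound 3

The source may hold more compounds than are shown below. What is called first, only, known or untested is meant among the compounds shown, and "the series" means these compounds.

In a functional assay (blood) for inhibition, with Homo sapiens as the target (on this read-out lower numbers stand for stronger inhibition and higher numbers for weaker inhibition), compound 1 `Cc1nc2ccc(COc3ccc4c(c3)c(SC(C)(C)C)c(CC(C)(C)C(=O)O)n4Cc3ccc(Cl)cc3)cc2s1` reads > 3000 nM as a limit of the assay. Among the compounds with values here, compound 2 `CC(COc1ccc2c(c1)c(SC(C)(C)C)c(CC(C)(C)C(=O)O)n2Cc1ccc(Cl)cc1)c1ccccn1` gives 270 nM as the only actual number so far. Compound 3 `CC(C)(C)Sc1c(CC(C)(C)C(=O)O)n(Cc2ccc(Cl)cc2)c2ccc(OCc3cnccn3)cc12` carries pyrazin-2-yl in place of 1-(pyridin-2-yl)ethyl on a saturated chain carbon bound to an oxygen on an aromatic ring. Within the data shown here, the only measured step at this place is an at least 11-fold lower number from compound 1 to compound 2 (1.04 log units; beyond the scatter) and it is large, but it involves a different group. A smaller move toward a higher number is therefore expected in this assay as the outcome. The expected step is a 2.2-fold higher number from compound 2 to compound 3 (0.35 log units; beyond the scatter) in size. For compound 3 the estimate is 600 nM with an expected range of 170 nM to 2000 nM for the measurement.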

Compound 3, half-maximal inhibitory concentration: 400 nM
Compound 3: the middle estimate sits 1.5-fold (0.18 log units) above what was measured; the measured number falls inside the stated range.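

In this assay, pyrazin-2-yl and 1-(pyridin-2-yl)ethyl on a saturated chain carbon bound to an oxygen on an aromatic ring cannot be told apart: a 1.5-fold higher number from compound 2 to compound 3 (0.17 log units; within the scatter). The lower number relative to 2-methyl-1,3-benzothiazol-6-yl therefore holds for a second group: an at least 7.5-fold lower number from compound 1 to compound 3 (0.87 log units; beyond the scatter). That step is only a bound, since the value of compound 1 is a limit of the assay: the limit of > 3000 nM in this assay, at which 1 of the 3 values shown sits.

The two groups differ in both ring and chain, so neither part can be credited alone. As far as these compounds go, how a phenyl or a morpholine would read at this place stays open.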